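The compounds below may be only part of what the source reports. "The series", "measured", "known", "first", "only" and "open" are said of these compounds alone.

Measured so far:
Compound 1 `COc1ccc(-c2nnc(NC(=O)/C=C/c3ccc(F)cc3)s2)cc1`: 0.85 ug/mL
Compound 2 `O=C(/C=C/c1ccc(F)cc1)Nc1nnc(-c2ccc(Br)cc2)s1`: 1.49 ug/mL
Compound 3 `O=C(/C=C/c1ccc(F)cc1)Nc1nnc(-c2ccccc2)s1`: 1.45 ug/mL

All three values come from a functional assay on MCF7 cells (Homo sapiens) for antiproliferative activity, read by MTT assay, with a stated time of 48 h; on this read-out higher numbers stand for weaker inhibition and lower numbers for stronger inhibition. Compound 1 gives 0.85 ug/mL, the lowest number shown, but its separation from the other two lies within the scatter: a 1.8-fold higher number from compound 1 to compound 2 (0.24 log units; within the scatter) and a 1.7-fold higher number from compound 1 to compound 3 (0.23 log units; within the scatter). The remaining pair is no more separated, with a 1.0-fold lower number from compound 2 to compound 3 (0.01 log units; within the scatter). No firm order can be read from these compounds.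

Compound 4 `COc1ccc(-c2nnc(NC(=O)/C=C/c3ccccc3)s2)cc1` departs from compound 1 at a different place, hydrogen in place of fluoro on an aromatic carbon, or 4-fluorophenyl to phenyl. Within the data shown here, no measured step covers this change, as all three alter the aromatic group that carries methoxy in compound 1. They bear on it only indirectly, showing that a 1.7-fold higher number from compound 1 to compound 3 (0.23 log units; within the scatter) stays within the scatter. In this assay, no step beyond the scatter is therefore expected, and the direction is uncertain. The estimated step is a 1.3-fold higher number from compound 1 to compound 4 (0.11 log units; within the scatter). Compound 4 is estimated at 1.1 ug/mL, with an expected range of 0.5 ug/mL to 2.5 ug/mL.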

Compound 4, half-maximal inhibitory concentration: 0.78 ug/mL
Estimate against measurement, compound 4: 1.4-fold (0.15 log units) above; the range from low to high includes it.
By their numbers in this assay, from the lowest: compounds 4, 1, 3 and 2 (each within the scatter of the next).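

In this assay, among these compounds, hydrogen in place of fluoro on the aromatic carbon gives a 1.1-fold lower number from compound 1 to compound 4 (0.04 log units; within the scatter), the first measured step at this position rather than on the aromatic group that carries methoxy in compound 1. The change from 4-fluorophenyl to phenyl therefore leaves no readable order between fluoro and hydrogen at this place, para to a large group, for this pair with methoxy retained. No supporting data bear on this result.

On these data alone, whether an amine or a carboxylic acid at this place would give a step beyond the scatter remains open. Also open, as far as these compounds go, is whether hydrogen in place of fluoro gives a similar step when the other aromatic group carries bromo or no substituent, as in compound 2 and compound 3.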